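The source may hold more compounds than are shown below. What is called first, only, known or untested is meant among the compounds shown, and "the series" means these compounds.

Compound 1 `Oc1ccccc1Nc1nccc(-c2c[nH]c3ccccc23)n1`: 120 nM
Compound 2 `COc1ccc(Nc2nccc(-c3sc(SC(C)C)nc3C)n2)c(OC)c1`: 1300 nM

In an assay for inhibition of MAP kinase-interacting serine/threonine-protein kinase 2 (Homo sapiens), read by TR-FRET (a lower number here means a stronger inhibitor, a higher number a weaker inhibitor), compound 2 gives 1300 nM, the higher of the two numbers shown, while compound 1 gives 120 nM, a gap beyond the usual scatter. Compound 3 `COCCSc1nc(C)c(-c2ccnc(Nc3ccc(OC)cc3OC)n2)s1` differs from compound 2 only by 2-methoxyethyl in place of isopropyl on a sulfur. Going by the values given here, no measured pair shows this change, so the step is expected to be small, in no particular direction and likely within the scatter. Compound 3 is therefore estimated at 1200 nM, with a range from 450 nM to 3500 nM. The expected step is a 1.1-fold lower number from compound 2 to compound 3 (0.03 log units; within the scatter).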

Compound 3, inhibition constant: 1700 nM
Compound 3: the middle estimate sits 1.4-fold (0.15 log units) below what was measured; the range from low to high includes it.
By their numbers in this assay, from the lowest: compound 1; then compounds 2 and 3 (each within the scatter of the next).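

In this assay, going by these compounds alone, 2-methoxyethyl in place of isopropyl on a sulfur gives a 1.3-fold higher number from compound 2 to compound 3 (0.12 log units; within the scatter), the first reading of a change at this position. Compound 2 and compound 3 cannot be told apart here, so the hydrogen-bond acceptor that 2-methoxyethyl carries and isopropyl lacks leaves no readable mark on the number. Nothing available offers an explanation for this result. On these data alone, whether an amine, a carboxylic acid or a longer chain on this sulfur would give a number beyond the scatter of these two remains open.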